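Thiosemicarbazone aryl variation: from compound 3 to compound 4

The source may report more compounds than this note shows. Statements on the series, on what has been measured and on what is new or still open speak of the compounds shown alone.

Compound 1 `CC1=CC[C@H](C(C)(C)NC(=S)N/N=C/c2ccc(O)cc2)CC1` in a functional assay on NCI-H460 cells (Homo sapiens) for inhibition, read by sulforhodamine B assay, with a stated time of 48 h (on this read-out higher numbers stand for weaker inhibition of growth and lower numbers for stronger inhibition of growth), gives > 100000 nM, a limit of the assay.
Compound 2 `CC1=CC[C@H](C(C)(C)NC(=S)N/N=C/c2ccccc2O)CC1` in this assay gives 1900 nM.
Compound 3 `CC1=CC[C@H](C(C)(C)NC(=S)N/N=C/c2ccc(F)cc2)CC1` in this assay gives > 100000 nM, a limit of the assay.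

Compound 3 thus stands at the upper edge of what is shown, as the limit of > 100000 nM in this assay, at which 2 of the 3 values shown sit, records; only compound 2, carrying 2-hydroxyphenyl, gives a number. Compound 4 `CC1=CC[C@H](C(C)(C)NC(=S)N/N=C/c2cccc(Cl)c2)CC1` differs from compound 3 by 3-chlorophenyl in place of 4-fluorophenyl on a carbon with a double bond to nitrogen. The steps that touch compound 3 are an at least 52-fold higher number from compound 2 to compound 3 (1.72 log units; beyond the scatter) and a step that the two limits leave unreadable from compound 1 to compound 3; both exchange a hydroxy-bearing phenyl for a halogen-bearing one, and none exchanges 4-fluorophenyl for 3-chlorophenyl. Nothing measured therefore reads directly on this change. Compound 4 is expected to stay near the limit, and the step of an at least 1.2-fold lower number from compound 3 to compound 4 (0.09 log units; that floor lies within the scatter) is expected to be none beyond the scatter. The estimate for compound 4 is 80000 nM, expected between 15000 nM and 300000 nM.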

Compound 4, concentration for 50% growth inhibition: 1400 nM
Compound 4: middle estimate off by 57-fold (1.76 log units), on the high side; measured number below the stated range.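

Exchanging 4-fluorophenyl for 3-chlorophenyl on a carbon with a double bond to nitrogen gives an at least 71-fold lower number from compound 3 to compound 4 (1.85 log units; beyond the scatter), so a halogen-bearing phenyl can leave the limit and no hydroxy group is needed for a number in this assay. The same group gives an at least 71-fold lower number from compound 1 to compound 4 (1.85 log units; beyond the scatter), whereas against 2-hydroxyphenyl it gives a 1.4-fold lower number from compound 2 to compound 4 (0.13 log units; within the scatter). Only compound 1 and compound 3 now stay at the limit: the limit of > 100000 nM in this assay, at which 2 of the 4 values shown sit.

On these data alone, whether the number follows the chlorine or its place on the ring stays open. So does the effect of an amine or a carboxylic acid on that ring.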